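The source may hold more compounds than are shown below. What is called first, only, known or untested is meant among the compounds shown, and "the series" means these compounds.

Measured so far in a functional assay on NCI-H226 cells (Homo sapiens) for inhibition, read by sulforhodamine B assay, with a stated time of 48 h, tested at 1 uM; a lower number here means a stronger effect, a higher number a weaker effect of the compound at the concentration tested:
- compound 1, `COc1cc(Cl)cc(-c2nn(-c3cccc(NC(=O)Nc4ccc(Cl)c(C(F)(F)F)c4)c3)cc2-c2ccncc2)c1`: 79%
- compound 2, `COc1cc(Cl)cc(-c2nn(-c3cccc(NC(=O)Nc4ccc(Cl)c(Cl)c4)c3)cc2-c2ccncc2)c1`: 82%

Compound 2 gives the higher of the two numbers, but its distance to compound 1 is small: a number 3 percentage points higher from compound 1 to compound 2 (within the scatter), so the two compounds cannot be told apart in this assay. Within the data shown here, that one measured step, chloro in place of trifluoromethyl on an aromatic carbon, is the only comparison available, and it bears only loosely on the next change.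

Compound 3, `COc1cc(Cl)cc(-c2nn(-c3cccc(NC(=O)Nc4cccc(C(F)(F)F)c4)c3)cc2-c2ccncc2)c1`, has not yet been measured in this assay. It differs from compound 2 in one place: 3-(trifluoromethyl)phenyl in place of 3,4-dichlorophenyl on an amide-type nitrogen. Compared with compound 1, compound 3 keeps the trifluoromethyl group and lacks the chloro group, but no step between those two compounds has been measured.

Among the measured compounds shown here, with only one within-scatter step to lean on, no shift beyond the scatter can be predicted with confidence, though the loss of a chloro group leaves slightly more room for a weaker effect. The step from compound 2 to compound 3 is therefore expected to be a number 3 percentage points higher from compound 2 to compound 3 (within the scatter). Compound 3 is estimated at 85%, within a range from 72% to 98%.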

Compound 3, a percentage reported as activity, at one concentration (the size of the read-out at that concentration, not a potency): 77%
Beside the measured number, compound 3's estimate is 8 percentage points above it; low and high end bracket the measured number.
By their numbers in this assay, from the lowest: compounds 3, 1 and 2 (each within the scatter of the next).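

In this assay there is now a step on the aryl group itself: swapping 3,4-dichlorophenyl for 3-(trifluoromethyl)phenyl on the amide-type nitrogen gives a number 5 percentage points lower from compound 2 to compound 3 (within the scatter) and so does not separate the two compounds. Removing only the chloro group, with the trifluoromethyl group kept, gives a number 2 percentage points lower from compound 1 to compound 3 (within the scatter) and likewise separates nothing, so in this pair the chloro group is not needed to hold the read-out within the scatter. Together with the earlier step, this means that all three aryl groups on this nitrogen give numbers that cannot be told apart at the single concentration tested, and no supporting measurement is available to explain the small differences that remain.

From the compounds shown here alone, all three aryl groups carry only halogen or trifluoromethyl substituents, so it remains open whether an amine or a carboxylic acid on this ring would move the number beyond the scatter. The shared core also stays the same throughout, which leaves open what a longer chain in place of its methoxy group would do.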